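This account rests on a few compounds, and the source may have more. Where it says the series, first, only, none or still open, it means among the compounds named here.

Measured so far:
- compound 1, `COc1cc2cc(C(=O)NCc3ccc(F)cc3)c(=O)oc2cc1OCCCOc1no[n+]([O-])c1S(=O)(=O)c1ccccc1`, 8460 nM
- compound 2, `COc1cc2cc(N)c(=O)oc2cc1OCCCOc1no[n+]([O-])c1S(=O)(=O)c1ccccc1`, 6450 nM

Both compounds share one core and differ only in the group on one aromatic carbon of that core. In an ADME assay on MCF-10A cells (Homo sapiens) for cytotoxicity, read by MTT assay, with a stated time of 48 h (on this read-out higher numbers stand for weaker inhibition and lower numbers for stronger inhibition), compound 1 gives 8460 nM, and in this assay compound 2 gives 6450 nM. Within the data shown here, compound 2 stands closest to compound 1, the only other measured compound, with a 1.3-fold lower number from compound 1 to compound 2 (0.12 log units; within the scatter); the two numbers therefore cannot be told apart.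

Compound 3, `COc1cc2cc(C(=O)Nc3ccc(F)cc3)c(=O)oc2cc1OCCCOc1no[n+]([O-])c1S(=O)(=O)c1ccccc1`, is not yet measured. It carries the change ((4-fluorophenyl)carbamoyl in place of amino on an aromatic carbon). Among the measured compounds shown here, the one measured step that bears on it is the step from compound 1 to compound 2, which swapped a (4-fluorobenzyl)carbamoyl group for the amino group at the same place and gave a 1.3-fold lower number from compound 1 to compound 2 (0.12 log units; within the scatter). For the measured compounds named here, the change to compound 3 runs the other way and installs a group that differs from the one in compound 1 only by the absence of the methylene link. A step of similar size, if any, is therefore expected, and it should stay within the scatter.

On this basis compound 3 is expected to give about 8000 nM in this assay, with a likely range from 4000 nM to 16000 nM, which amounts to an expected 1.2-fold higher number from compound 2 to compound 3 (0.09 log units; within the scatter).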

Compound 3, half-maximal inhibitory concentration: 7210 nM
Compound 3: the middle estimate sits 1.1-fold (0.05 log units) above what was measured; low and high end bracket the measured number.
By their numbers in this assay, from the lowest: compounds 2, 3 and 1 (each within the scatter of the next).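

In this assay, the step to (4-fluorophenyl)carbamoyl in place of amino is a 1.1-fold higher number from compound 2 to compound 3 (0.05 log units; within the scatter), so a group of 10 heavy atoms with a six-membered aromatic ring can stand on this aromatic carbon of the shared core without a readable shift in the number. Dropping the methylene link, with 4-fluorophenyl in place of 4-fluorobenzyl on the amide-type nitrogen, gives a 1.2-fold lower number from compound 1 to compound 3 (0.07 log units; within the scatter), so the link also makes no readable difference here. The small amino group and both larger amide groups therefore cannot be told apart at this position, and no information at hand explains this.

On these data alone, it remains open whether a different group at this place, such as a carboxylic acid, a phenyl ring without fluorine or a longer chain between the amide nitrogen and the fluorophenyl ring, would move the number beyond the scatter. As far as these compounds go, it is also open whether these three groups would stay equally close together on other cell types.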